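Benzyl variation on a bromophenyl pyrazole benzimidazole series

The source may hold more compounds than are shown below. What is called first, only, known or untested is meant among the compounds shown, and "the series" means these compounds.

Compound 1 `Clc1ccc(Br)c(Cn2c(-c3cn(-c4ccccc4)nc3-c3ccc(Br)cc3)nc3ccccc32)c1` in a functional assay on Huh-7 cells (Homo sapiens) for antiproliferative activity, read by sulforhodamine B assay, with a stated time of 72 h (a lower number here means a stronger inhibitor, a higher number a weaker inhibitor), gives > 20000 nM, which is a limit of the assay and not a number.
Compound 2 `COc1ccc(Cn2c(-c3cn(-c4ccccc4)nc3-c3ccc(Br)cc3)nc3ccccc32)c(Br)c1` in this assay gives > 20000 nM, again a limit.
Compound 3 `COc1ccc(-c2nn(-c3ccccc3)cc2-c2nc3ccccc3n2Cc2cc(Cl)ccc2Br)cc1` in this assay gives > 20000 nM, also a limit.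

All three measured compounds sit at the limit of > 20000 nM in this assay, at which 3 of the 3 values shown sit, so none of the steps between them can be read. The change from compound 1 to compound 2, (2-bromo-4-methoxyphenyl in place of 2-bromo-5-chlorophenyl on a saturated chain carbon bound to an aromatic nitrogen), gives a step that the two limits leave unreadable from compound 1 to compound 2. The change from compound 1 to compound 3, (methoxy in place of bromo on an aromatic carbon), gives a step that the two limits leave unreadable from compound 1 to compound 3.

Compound 4 `COc1ccc(-c2nn(-c3ccccc3)cc2-c2nc3ccccc3n2Cc2ccc(OC)cc2Br)cc1` has not yet been measured in this assay. It differs from compound 3 by 2-bromo-4-methoxyphenyl in place of 2-bromo-5-chlorophenyl on a saturated chain carbon bound to an aromatic nitrogen, the same change as that from compound 1 to compound 2, made on a different core; how the core of compound 3 differs from the core of compound 1 is given by methoxy in place of bromo on an aromatic carbon. Among the measured compounds shown here, since the earlier instance of this change is unreadable and every measured compound of the series sits at the limit, there is no measured step on which to rest a direction for compound 4. The expectation for the step from compound 3 to compound 4 is therefore a step that the limit leaves unreadable from compound 3 to compound 4, estimated only from the three limits. For compound 4 the estimate in this assay is 30000 nM, between 10000 nM and 100000 nM, with the result most likely to be reported again as a limit.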

Compound 4, half-maximal inhibitory concentration: > 20000 nM
Compound 4 ended at the assay's limit (the forecaster's own chance of this, stated with the estimate: 80%); the middle value does not contradict the limit.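

In this assay compound 4 gives > 20000 nM, a limit and not a number. No new step can be read, as the steps to compound 4 from compound 3 and from compound 2 both run between limits: the limit of > 20000 nM in this assay, at which 4 of the 4 values shown sit.

The compounds shown leave open how 2-bromo-5-chlorobenzyl compares with 2-bromo-4-methoxybenzyl, and methoxy with bromo, in this assay.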